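Removing one methoxy from compound 3: expected paw edema inhibition

The compounds below may be only part of what the source reports. "The series", "measured", "known", "first", "only" and "open" are said of these compounds alone.

Of the compounds shown here, three have been tested in a functional assay on the whole organism (strain albino) for inhibition, with Rattus norvegicus as the target, read by paw edema, with a stated time of 1 h, at a dose of 0.28 mmol/kg by the oral route; a lower number here means less inhibition, a higher number more inhibition at the dose given (going by the name of the read-out). Compound 1 `COc1ccc(-c2nnc(SC/C(=N/O)c3ccccc3)n2-c2ccccc2)cc1OC` gives 55%. Compound 2 `CCn1c(SCC(=O)c2ccccc2)nnc1-c1cc(OC)c(OC)c(OC)c1` gives 29%. Compound 3 `CCn1c(SC/C(=N/O)c2ccccc2)nnc1-c1cc(OC)c(OC)c(OC)c1` gives 63%. Among the measured compounds shown here, the one single-point step measured so far is a number 34 percentage points higher from compound 2 to compound 3 (beyond the scatter), on the saturated chain carbon bound to the sulfur. Compound 3 and compound 1 lie within the usual scatter of each other; compound 2 lies beyond the scatter below both.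

Compound 4 `CCn1c(SC/C(=N/O)c2ccccc2)nnc1-c1ccc(OC)c(OC)c1` differs from compound 3 by hydrogen in place of methoxy on an aromatic carbon. For the measured compounds named here, no measured step touches this aromatic ring. Going by the values given here, the only comparison available is between compound 1, carrying two methoxy groups, and compound 3, carrying three, and their numbers in this assay sit within the scatter, although they also differ on the nitrogen of the shared core. The change is therefore expected to give no step beyond the scatter, and a number 5 percentage points lower from compound 3 to compound 4 (within the scatter) is the estimated step. Compound 4 is expected to give 58%, with a range from 40% to 75%.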

Compound 4, a percentage reported as inhibition, in the whole organism at one dose (the size of the read-out at that dose, not a potency): 61%
The estimate for compound 4 lay 3 percentage points below the measured number; measured number inside the range.
By their numbers in this assay, from the lowest: compound 2; then compounds 1, 4 and 3 (each within the scatter of the next).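

In this assay, hydrogen in place of methoxy on this aromatic carbon gives a number 2 percentage points lower from compound 3 to compound 4 (within the scatter), so this first direct reading at the position shows that the methoxy can leave without a step beyond the scatter. Ethyl in place of phenyl on an aromatic nitrogen gives a number 6 percentage points higher from compound 1 to compound 4 (within the scatter), which separates the two changes that were combined between compound 1 and compound 3 and shows that this change, too, stays within the scatter. No measurement given here bears on the reason for either result.

From the compounds shown here alone, whether an amine or a chlorine on this aromatic carbon would also stay within the scatter remains open. So does the outcome of a longer chain in place of ethyl on the aromatic nitrogen.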